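Pyrimidin-2-yl in place of 4-fluorophenyl on the carbonyl carbon

The compounds below may be only part of what the source reports. "The series", "measured", "known", "first", "only" and "open" are said of these compounds alone.

In a functional assay on COR-L23 cells (Homo sapiens) for antiproliferative activity, read by CellTiter-Glo, with a stated time of 4 days (on this read-out higher numbers stand for weaker inhibition and lower numbers for stronger inhibition), compound 1 (`C[C@H](NC(=O)C1CCOCC1)c1ccc(NC(=O)[C@H]2C[C@@H]2c2cccnc2)cc1`) gives 7 nM and compound 2 (`C[C@H](NC(=O)c1ccc(F)cc1)c1ccc(NC(=O)[C@H]2C[C@@H]2c2cccnc2)cc1`) gives 12 nM with the two values within the scatter of each other. Compound 3 (`C[C@H](NC(=O)c1ncccn1)c1ccc(NC(=O)[C@H]2C[C@@H]2c2cccnc2)cc1`) has pyrimidin-2-yl in place of the 4-fluorophenyl of compound 2 on a carbonyl carbon (pyrimidin-2-yl in place of 4-fluorophenyl on a carbonyl carbon). Within the data shown here, the only measured step at this carbonyl carbon (a 1.7-fold higher number from compound 1 to compound 2 (0.23 log units; within the scatter)) stays within the scatter, and no measured compound carries pyrimidin-2-yl. The expected step in this assay (a 1.3-fold higher number from compound 2 to compound 3 (0.10 log units; within the scatter)) is therefore none beyond the scatter. Compound 3 is estimated at 15 nM (expected range 5 nM to 45 nM).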

Compound 3, half-maximal inhibitory concentration: 17 nM
Compound 3: middle estimate off by 1.1-fold (0.05 log units), on the low side; measured number inside the range.
By their numbers in this assay, from the lowest: compounds 1, 2 and 3 (each within the scatter of the next, the first and the last beyond it).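

In this assay the carbonyl carbon accepts pyrimidin-2-yl in place of 4-fluorophenyl with a 1.4-fold higher number from compound 2 to compound 3 (0.15 log units; within the scatter), so the two hetero atoms of the new ring leave no change that can be read. Against oxan-4-yl, the same group gives a 2.4-fold higher number from compound 1 to compound 3 (0.39 log units; beyond the scatter), the first step at this carbonyl carbon to leave the scatter, though only a modest one. Nothing available explains that step.

Still open, from the compounds shown here alone, is how an amine or a carboxylic acid on the aromatic ring would fare here. Going by these compounds, whether a longer chain in place of oxan-4-yl would hold the number is equally open.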